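The source may report more compounds than this note shows. Statements on the series, on what has been measured and on what is new or still open speak of the compounds shown alone.

Measured in a functional assay on KB cells (Homo sapiens) for inhibition, read by MTT assay, with a stated time of 24 h, tested at 1 ug/mL; a lower number here means less inhibition of growth, a higher number more inhibition of growth at the concentration tested:
- compound 1 `O=C(CCCCC1CCSS1)Nc1ccc([N+](=O)[O-])c(C(F)(F)F)c1`: "not active" (no number reported)
- compound 2 `CC(=O)SCCC(CCCCC(=O)Nc1ccccc1Cl)SC(C)=O`: 8.21%

Going by the values given here, compound 2 holds the only number so far, as compound 1 gives "not active" (no number reported) with no figure attached. There is therefore no ranking to speak of, and compound 2 stands alone as the single numerical reference point.

Next in line is compound 3 `CC(=O)SCCC(CCCCC(=O)Nc1ccc(Cl)cc1)SC(C)=O`, which has the same atoms as compound 2, joined differently. The change is 4-chlorophenyl in place of 2-chlorophenyl on an amide-type nitrogen. The rest of the structure stays the same.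

Among the compounds with values here, no pair of measured compounds shows what a step of this kind does in this assay, so the expectation rests on compound 2 at 8.21% alone. No step beyond the usual scatter is expected, and neither direction is favoured. The expected change is a number 1.8 percentage points higher from compound 2 to compound 3 (within the scatter), a small estimated step. The estimate for compound 3 is 10%, with an expected range of 2% to 28%.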

Compound 3, percent growth inhibition at one concentration: 14.8%
Compound 3: middle estimate off by 4.8 percentage points, on the low side; the range from low to high includes it.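

In this assay, going by these compounds alone, 4-chlorophenyl in place of 2-chlorophenyl on an amide-type nitrogen gives a number 6.6 percentage points higher from compound 2 to compound 3 (within the scatter) as the first step that can be read. The earlier compounds shown here offered no pair differing in one place, and this pair now shows that, at the single concentration tested, the two chlorophenyl groups cannot be told apart on this nitrogen, with the rest of the structure held constant. Nothing measured on these compounds bears on the result, so it stands as an observation without an explanation.

What the series leaves open is whether this nitrogen responds to a larger change than the swap of one chlorophenyl group for the other, such as a plain phenyl, a methoxyphenyl or an aminophenyl group, or a carboxylic acid on the ring. Also open, from the compounds shown here alone, is what the two acetylthio groups contribute, since a comparison with the free thiols or with the closed disulfide ring of compound 1 on the same chlorophenyl amide would be needed, and compound 1 itself differs from compound 2 and compound 3 in more than one place.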